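Swapping the aryl group on the thiazolidinone carbon

The compounds below may be only part of what the source reports. "The series", "measured", "known", "first", "only" and "open" are said of these compounds alone.

Compound 1, `COc1ccc(C2SCC(=O)N2NC(=O)CN2C(=O)c3ccccc3C2=O)cc1`, stands at the low end of the three measured numbers in a physicochemical assay for lipophilicity, in phosphate buffer, measured as octanol-water partition, with a stated time of 24 h (a lower number here means a more polar compound, a higher number a more lipophilic compound), giving 1.97. Compound 2, `Cc1ccc(C2SCC(=O)N2NC(=O)CN2C(=O)c3ccccc3C2=O)cc1`, gives 2.97, and compound 3, `O=C(CN1C(=O)c2ccccc2C1=O)NN1C(=O)CSC1c1cccs1`, gives 2.15. The step from compound 1 to compound 2 is a number 1.00 log units higher from compound 1 to compound 2 (beyond the scatter), while the step from compound 1 to compound 3 is a number 0.18 log units higher from compound 1 to compound 3 (within the scatter). Compound 4, `O=C(CN1C(=O)c2ccccc2C1=O)NN1C(=O)CSC1c1cccnc1`, differs from compound 1 as follows: pyridin-3-yl in place of 4-methoxyphenyl on a saturated ring carbon. Among the compounds with values here, the only measured step at the same saturated ring carbon, a number 0.18 log units higher from compound 1 to compound 3 (within the scatter), exchanges one aromatic ring for another without leaving the scatter; no measured step introduces a nitrogen into an aromatic ring. The change in compound 4 removes an oxygen-bearing six-membered ring and brings in a six-membered ring with one nitrogen, so a step downward in this assay of modest size is expected, a number 0.97 log units lower from compound 1 to compound 4 (beyond the scatter). Compound 4 is therefore estimated at 1, with a range from 0.4 to 1.6.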

Compound 4, partition coefficient: 1.25
The estimate for compound 4 lay 0.25 log units below the measured number, within the range that was stated.
By their numbers in this assay, from the lowest: compound 4; then compounds 1 and 3 (each within the scatter of the next); then compound 2.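

In this assay, pyridin-3-yl gives the first downward step from compound 1 at this saturated ring carbon, a number 0.72 log units lower from compound 1 to compound 4 (beyond the scatter), whereas thiophen-2-yl stayed within the scatter of 4-methoxyphenyl. The same change also separates compound 4 from the other two compounds, with a number 0.90 log units lower from compound 3 to compound 4 (beyond the scatter) and a number 1.72 log units lower from compound 2 to compound 4 (beyond the scatter), the widest step among the compounds shown, and leaves compound 4 with the lowest number of the four. Nothing available accounts for the size of these steps.

The compounds shown leave open whether pyridin-2-yl or pyridin-4-yl would read like pyridin-3-yl on this carbon. They also leave open how a phenyl ring bearing an amine or a carboxylic acid would read here.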